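Swapping the sulfonyl substituent: compound 1 to compound 3

The compounds below may be only part of what the source reports. "The series", "measured", "known", "first", "only" and "open" are said of these compounds alone.

Measured so far:
- compound 1, `CNC(=O)c1cc(S(=O)(=O)N2CCS[C@H]2C(=O)O[C@@H](Cc2c(Cl)c[n+]([O-])cc2Cl)c2ccc(OC(F)F)c(OCC3CC3)c2)cn1C`: 47.6 uL/min
- compound 2, `CN(C)C(=O)c1cccc(S(=O)(=O)N2CCCC[C@H]2C(=O)O[C@@H](Cc2c(Cl)c[n+]([O-])cc2Cl)c2ccc(OC(F)F)c(OCC3CC3)c2)c1`: 64.6 uL/min

Both compounds were tested in an ADME assay on cells (Hepatocyte, Homo sapiens) for metabolic stability, read by LC-MS, with a stated time of 90 min, tested at 1 uM; a lower number here means slower removal, a higher number faster removal of the compound. Compound 1 gives 47.6 uL/min and compound 2 gives 64.6 uL/min; the gap between them lies within the scatter, so the two cannot be told apart, and compound 1 simply has the lower of the two numbers.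

Compound 3, `COc1ccc(S(=O)(=O)N2CCS[C@H]2C(=O)O[C@@H](Cc2c(Cl)c[n+]([O-])cc2Cl)c2ccc(OC(F)F)c(OCC3CC3)c2)cc1OC`, has not yet been measured. It differs from compound 1 in one place: a group of 10 heavy atoms (8 carbon, 2 oxygen; one six-membered aromatic ring of carbon only) in place of a group of 10 heavy atoms (7 carbon, 2 nitrogen, 1 oxygen; one five-membered aromatic ring with 1 hetero atom), on a sulfonyl sulfur.

Within the data shown here, no measured pair shows what this kind of change does, so the expectation rests on compound 1 alone. Compound 3 is expected to give 70 uL/min, with a range from 35 uL/min to 140 uL/min. The expected step is a 1.5-fold higher number from compound 1 to compound 3 (0.17 log units; within the scatter), a modest rise that may well fall within the scatter.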

Compound 3, intrinsic clearance in a liver preparation (reported as CLH), per the amount of preparation that the assay uses: 53.8 uL/min
For compound 3 the middle estimate is 1.3-fold (0.11 log units) above the measured one; the range from low to high includes it.
By their numbers in this assay, from the lowest: compounds 1, 3 and 2 (each within the scatter of the next).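

In this assay putting 3,4-dimethoxyphenyl on the sulfonyl sulfur, in place of the group with the five-membered aromatic ring, gives a 1.1-fold higher number from compound 1 to compound 3 (0.05 log units; within the scatter) and leaves compound 1 and compound 3 impossible to tell apart. Among these compounds, this is the first comparison that isolates this position, and it shows that a six-membered carbon ring with no hydrogen-bond donor can stand in for a five-membered ring group with one, with the read-out staying within the scatter. Nothing measured here explains why the two groups read alike.

The compounds shown leave open whether a quite different group on the sulfonyl sulfur, such as an amine or a carboxylic acid, would move the number beyond the scatter. They also leave open whether 3,4-dimethoxyphenyl would behave the same way on the sulfonamide ring of compound 2.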